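Methoxycarbonyl in place of isopropyl: working notes on four compounds

The source may hold more compounds than are shown below. What is called first, only, known or untested is meant among the compounds shown, and "the series" means these compounds.

Measured so far in a functional assay on HEK293 cells for agonist activity at transient receptor potential cation channel subfamily V member 1 (Homo sapiens), read by calcium flux; a lower number here means that less compound is needed, a higher number that more compound is needed for the effect:
compound 1, `CC(C)Cn1nnc(Cc2ccc(-c3ccccc3)cc2)n1`: 10000 nM
compound 2, `COC(=O)Cn1nnc(Cc2ccc(-c3ccccc3)cc2)n1`: a limit of the assay, > 100000 nM
compound 3, `CC(C)Cn1nnc(CNC(=O)c2ccc(-c3ccccc3)cc2)n1`: 53500 nM

Compound 3 carries the highest of the two numbers; compound 1 is nearest. The difference between the cores of compound 3 and compound 1 is not broken down here. Compound 1 and compound 2 differ by methoxycarbonyl in place of isopropyl on a saturated chain carbon bound to an aromatic nitrogen, and this step reads an at least 10-fold higher number from compound 1 to compound 2 (1.00 log units; beyond the scatter); the value of compound 2 sits at the limit of > 100000 nM in this assay, at which 1 of the 3 values shown sits.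

Compound 4, `COC(=O)Cn1nnc(CNC(=O)c2ccc(-c3ccccc3)cc2)n1`, is not yet measured. It relates to compound 3 by methoxycarbonyl in place of isopropyl on a saturated chain carbon bound to an aromatic nitrogen, the same change at the same place as between compound 1 and compound 2.

For compound 4 a step of a 5.6-fold higher number from compound 3 to compound 4 (0.75 log units; beyond the scatter) is expected, because the same change gave an at least 10-fold higher number from compound 1 to compound 2 (1.00 log units; beyond the scatter). Since compound 3 already stands at 53500 nM, compound 4 is expected to give a higher number still. The estimate for compound 4 is 300000 nM, with a range from 100000 nM to 1000000 nM.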

Compound 4, half-maximal effective concentration: > 100000 nM
Compound 4 was reported as a limit; the forecaster's own chance of this, stated with the estimate: 80%; the middle value is on the limit's open side.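

In this assay compound 4 gives > 100000 nM, which is a limit of the assay and not a number. On this core, methoxycarbonyl in place of isopropyl gives an at least 1.8-fold higher number from compound 3 to compound 4 (0.27 log units; that floor lies within the scatter); the direction agrees with the earlier step, but the floor alone does not establish a change beyond the scatter. The data therefore show no reversal of the change on the second core, and they do not show that its size carries over from one core to the other: the same change on two cores in this assay, an at least 10-fold higher number (1.00 log units; beyond the scatter) from compound 1 to compound 2 and an at least 1.8-fold higher number (0.27 log units; that floor lies within the scatter) from compound 3 to compound 4; the limit leaves it open whether they differ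

From the compounds shown here alone, compound 2 and compound 4, the two methoxycarbonyl compounds, both leave the full size of the change unread: the limit of > 100000 nM in this assay, at which 2 of the 4 values shown sit. Also open is whether a carboxylic acid or a longer chain in place of isobutyl, on the core of compound 1 or of compound 3, would give a number that can be read in this assay and compared across the two cores.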